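Notes on the aromatic end group of the series

The source may hold more compounds than are shown below. What is called first, only, known or untested is meant among the compounds shown, and "the series" means these compounds.

Values in a functional assay on PCO3 cells (Homo sapiens) for cytotoxicity, read by sulforhodamine B assay; on this read-out higher numbers stand for weaker inhibition of growth and lower numbers for stronger inhibition of growth:
compound 1 `CC1=CC[C@@H]([C@@](C)(O)CCCC(C)(C)NC(=S)N/N=C\c2ccc(O)cc2)CC1`: 13900 nM
compound 2 `CC1=CC[C@@H]([C@@](C)(O)CCCC(C)(C)NC(=S)N/N=C\c2cccc([N+](=O)[O-])c2)CC1`: 20700 nM
compound 3 `CC1=CC[C@@H]([C@@](C)(O)CCCC(C)(C)NC(=S)N/N=C\c2ccc([N+](=O)[O-])cc2)CC1`: > 100000 nM, which is a limit of the assay and not a number.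

Compound 1 and compound 2 sit within the scatter of each other, as a 1.5-fold higher number from compound 1 to compound 2 (0.17 log units; within the scatter) shows. Against them, an at least 7.1-fold higher number from compound 1 to compound 3 (0.85 log units; beyond the scatter) and an at least 4.8-fold higher number from compound 2 to compound 3 (0.68 log units; beyond the scatter) are beyond the scatter, both resting on (the limit of > 100000 nM in this assay, at which 1 of the 3 values shown sits).

Compound 4 `CC1=CC[C@@H]([C@@](C)(O)CCCC(C)(C)NC(=S)N/N=C(/C)c2ccccc2)CC1` differs from compound 1 by a group of 9 heavy atoms (8 carbon, 1 nitrogen; one six-membered aromatic ring of carbon only) in place of a group of 9 heavy atoms (7 carbon, 1 nitrogen, 1 oxygen; one six-membered aromatic ring of carbon only), on an amide-type nitrogen; in words, a group of 9 heavy atoms (8 carbon, 1 nitrogen; one six-membered aromatic ring of carbon only) in place of a group of 9 heavy atoms (7 carbon, 1 nitrogen, 1 oxygen; one six-membered aromatic ring of carbon only), on an amide-type nitrogen. Within the data shown here, no measured step removes the hydroxy or adds a methyl group on the carbon with a double bond to nitrogen, so the two nitro steps bear on it only loosely: they show that changing the aromatic end group can leave this assay unchanged, as for compound 2, or weaken growth inhibition, as for compound 3. Compound 4 is therefore expected somewhat weaker than compound 1, with a 1.8-fold higher number from compound 1 to compound 4 (0.25 log units; within the scatter) as the estimated step. The estimate for compound 4 is 25000 nM, within 8000 nM to 100000 nM.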

Compound 4, concentration for total growth inhibition: > 100000 nM
Compound 4: no number, only a limit; the forecaster's own chance of this, stated with the estimate: 25%; middle value at least 4.0-fold (0.60 log units) from the limit.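

In this assay compound 4 stands at > 100000 nM, which is a limit of the assay and not a number. Until now, only the nitro compound 3 had reached this limit; compound 4 shows that the end group can reach it without any nitro group. The change on the amide-type nitrogen gives an at least 7.1-fold higher number from compound 1 to compound 4 (0.85 log units; beyond the scatter), and this step is only a lower bound on the change, as it rests on the ceiling of the assay: the limit of > 100000 nM in this assay, at which 2 of the 4 values shown sit.

Whether the loss of the hydroxy or the methyl group on the carbon with a double bond to nitrogen carries this step stays open, as the compounds shown hold neither change alone. Also open, from the compounds shown here alone, is how an amine or a methoxy group in place of the hydroxy would read here.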